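One Methoxy Fewer at the Limit of the Assay

This account rests on a few compounds, and the source may have more. Where it says the series, first, only, none or still open, it means among the compounds named here.

In a functional assay on HCT-116 cells (Homo sapiens) for cytotoxicity, read by MTT assay (on this read-out lower numbers stand for stronger inhibition and higher numbers for weaker inhibition), compound 1 `Cc1cc(O)c(C(=O)/C=C/c2ccccc2F)c(=O)o1` gives > 100000 nM as a limit of the assay and not a number. Compound 2 `COc1ccc(/C=C/C(=O)c2c(O)cc(C)oc2=O)c(OC)c1` gives > 100000 nM as a limit as well, so it offers no exact potency as a starting point. The two compounds share a single ceiling (the limit of > 100000 nM in this assay, at which 2 of the 2 values shown sit) and cannot be ranked against each other.

Compound 3 `COc1ccccc1/C=C/C(=O)c1c(O)cc(C)oc1=O` differs from compound 2 by one change (hydrogen in place of methoxy on an aromatic carbon) with hydrogen in place of methoxy on an aromatic carbon, meta to a methoxy group and para to a large group. For the measured compounds named here, no step between measured compounds is available to size this change in this assay and any expectation therefore remains loose. With compound 2 at > 100000 nM as a limit, there is no measured sign that this change would matter. The expected size of a number no higher from compound 2 to compound 3 (the limit leaves the size open) is none beyond the usual scatter, in either direction. For compound 3 the estimated value is 100000 nM with an expected range from 40000 nM to 200000 nM and it may well prove to be a limit again.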

Compound 3, half-maximal inhibitory concentration: > 100000 nM
Compound 3 was reported as a limit; the forecaster's own chance of this, stated with the estimate: 75%; the middle value lies on the limit itself.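

Compound 3 joins compound 1 and compound 2 at a single ceiling in this assay, so the steps to compound 3 from either of them cannot be read and the three compounds cannot be ranked: the limit of > 100000 nM in this assay, at which 3 of the 3 values shown sit.

The compounds shown leave open whether any change on the shared core would give a measurable number in this assay.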